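The source may hold more compounds than are shown below. What is called first, only, known or untested is meant among the compounds shown, and "the series" means these compounds.

compound 1 `Cc1ccc(S(=O)(=O)Nc2ccc3oc(-c4ccccc4)nc3c2)cc1` — > 100000 nM
compound 2 `O=S(=O)(Nc1ccc(-c2nc3ccccc3o2)cc1)c1ccccc1O` — > 100000 nM

Both measured compounds were tested in an assay on cells for inhibition of HSP60/HSP10 (Homo sapiens), with a stated time of 60 min; a lower number here means a stronger inhibitor, a higher number a weaker inhibitor. For compound 1 the result of > 100000 nM is a limit rather than a number. For compound 2 the result of > 100000 nM is likewise only a limit. Compound 1 therefore stands at the edge of what this assay can report, and so does everything measured so far: the limit of > 100000 nM in this assay, at which 2 of the 2 values shown sit. Among the measured compounds shown here, no step between two measured compounds exists, so nothing yet shows how a change on the sulfonyl sulfur moves the numbers in this assay.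

Compound 3 `O=S(=O)(Nc1ccc2oc(-c3ccccc3)nc2c1)c1ccc(Cl)c(Cl)c1` has not been measured. Its difference from compound 1 is 3,4-dichlorophenyl in place of 4-methylphenyl on a sulfonyl sulfur. For the measured compounds named here, with no measured step to lean on, the expectation is that this change gives no step beyond the scatter, and that compound 3 most likely again gives only a limit in this assay. The step expected is a step that the limit leaves unreadable from compound 1 to compound 3. Compound 3 is estimated at 150000 nM, with a range from 30000 nM to 600000 nM.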

Compound 3, half-maximal inhibitory concentration: > 100000 nM
Compound 3: only a limit was reported (the forecaster's own chance of this, stated with the estimate: 80%); the middle value is on the limit's open side.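

Among the compounds shown here, compound 3 gives only a limit in this assay, as compound 1 does, so the swap to 3,4-dichlorophenyl yields no step that can be read. All results shown sit at the same edge: the limit of > 100000 nM in this assay, at which 3 of the 3 values shown sit. The compounds shown leave open which structural change, if any, would give an actual number rather than a limit in this assay.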